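The source may report more compounds than this note shows. Statements on the series, on what has been measured and on what is new or still open speak of the compounds shown alone.

Measured compounds in a functional assay on HeLa cells (Homo sapiens) for antiproliferative activity, read by CCK-8 assay, with a stated time of 72 h, tested at 8 uM; on this read-out lower numbers stand for a weaker effect and higher numbers for a stronger effect at the one concentration tested:
- compound 1, `CC1CCCCN1C(=S)SCc1ccc(C(=O)Nc2ccccc2N)cc1`: in this assay compound 1 gives 76.3%
- compound 2, `CC1CCN(C(=S)SCc2ccc(C(=O)Nc3ccccc3N)cc2)CC1`: in this assay compound 2 gives 72.5%
- compound 3, `CN(Cc1cccnc1)C(=S)SCc1ccc(C(=O)Nc2ccccc2N)cc1`: in this assay compound 3 gives 68.7%

All three compounds share the same core and differ only in the group on the thiocarbonyl carbon. The step of a number 3.8 percentage points lower from compound 1 to compound 2 (within the scatter) and the step of a number 7.6 percentage points lower from compound 1 to compound 3 (within the scatter) are both within the scatter, as is the step of a number 3.8 percentage points lower from compound 2 to compound 3 (within the scatter), so on the numbers shown compound 3 cannot be told apart from compounds 1 and 2 in this assay.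

Compound 4, `CN(Cc1ccncc1)C(=S)SCc1ccc(C(=O)Nc2ccccc2N)cc1`, is not yet measured. It differs from compound 3 in one place: pyridin-4-yl in place of pyridin-3-yl on a saturated chain carbon bound to an amide-type nitrogen. Among the compounds with values here, no measured step changes a pyridine ring in this way, so the nearest guide is the pattern among compounds 1, 2 and 3, where every change on the thiocarbonyl carbon stayed within the scatter in this assay. A step of no size beyond the scatter is therefore expected, in neither direction.

Compound 4 is thus estimated at 68% in this assay, with a range from 55% to 80%, which means an expected step of a number 0.7 percentage points lower from compound 3 to compound 4 (within the scatter).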

Compound 4, a percentage reported as inhibition, at one concentration (the size of the read-out at that concentration, not a potency): 72.7%
Estimate against measurement, compound 4: 4.7 percentage points below, and the stated range covers the measured number.
By their numbers in this assay, from the lowest: compounds 3, 2, 4 and 1 (each within the scatter of the next).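

In this assay, pyridin-4-yl in place of pyridin-3-yl on a saturated chain carbon bound to an amide-type nitrogen gives a number 4 percentage points higher from compound 3 to compound 4 (within the scatter), so these two rings, made of the same atoms joined differently, cannot be told apart here. Within the data shown here, this is the first direct test of the pyridine ring itself, and methyl((pyridin-4-yl)methyl)amino also cannot be separated from the two methylpiperidinyl groups on the thiocarbonyl carbon, with a number 0.2 percentage points higher from compound 2 to compound 4 (within the scatter) and a number 3.6 percentage points lower from compound 1 to compound 4 (within the scatter). No separate measurement bearing on this result is available.

As far as these compounds go, because each compound was read at one concentration, these numbers show the size of the effect rather than potency, so differences in potency remain open. Also open, from the compounds shown here alone, is whether pyridin-2-yl on the same carbon, or a longer chain carrying the pyridine ring, would give a step beyond the scatter.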